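A few compounds are considered here, and "the series" means these few. Any claim that something is new, unique, unknown or untested is made for them only; others in the source may bear on it.

For the measured compounds named here, compound 2, `C#CCNC(=O)/C=C/c1cnc(Nc2ccc(C#N)cc2)nc1Oc1c(C)cc(C#N)cc1C`, is one of two compounds measured in an ADME assay on TZM cells (Homo sapiens) for cytotoxicity, with a stated time of 1 days (on this read-out higher numbers stand for lower toxicity in this test and lower numbers for higher toxicity in this test), and its own result is a limit rather than a number: in this assay compound 2 reaches > 222 nM. Compound 1, `CCOC(=O)/C=C/c1cnc(Nc2ccc(C#N)cc2)nc1Oc1c(C)cc(C#N)cc1C`, differs from it only in carrying an ethoxy on the carbonyl carbon where compound 2 carries a propargylamino. In this assay compound 1 likewise returns a limit, > 227 nM. Going by the values given here, the single step available, a step that the two limits leave unreadable from compound 1 to compound 2, is therefore not readable in size, the two results sitting at the limit of > 222 nM in this assay, at which 1 of the 2 values shown sits, and (the limit of > 227 nM in this assay, at which 1 of the 2 values shown sits).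

Compound 3, `Cc1cc(C#N)cc(C)c1Oc1nc(Nc2ccc(C#N)cc2)ncc1/C=C/C(=O)NCCOCCO`, has not yet been measured in this assay. Its structural difference from compound 2 is (2-hydroxyethoxy)methyl in place of ethynyl on a saturated chain carbon bound to an amide-type nitrogen.

Among the compounds with values here, since the only measured step is unreadable and both measured compounds ended at limits, there is no basis to expect a step beyond the scatter; the estimate for the step is a step that the limit leaves unreadable from compound 2 to compound 3, meaning no change is expected. Compound 3 is accordingly estimated at 300 nM in this assay, with a range from 150 nM to 2000 nM, and most likely it too would return only a limit.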

Compound 3, half-maximal cytotoxic concentration: > 200 nM
Compound 3: only a limit was reported; the forecaster's own chance of this, stated with the estimate: 80%; the middle value does not contradict the limit.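

Compound 3, like compound 1 and compound 2, gives only a limit in this assay, so none of the steps linking compound 3 to compound 1 or compound 2 can be read. The compounds shown leave open where the half-maximal cytotoxic concentration of each actually lies, and whether any of these side-chain changes alters it.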